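The compounds below may be only part of what the source reports. "The series", "measured", "known", "first", "only" and "open" are said of these compounds alone.

Compound 2 `COc1cc(-c2nn(-c3cccc(NC(=O)c4ccc(Cl)c(C(F)(F)F)c4)c3)cc2-c2ccncc2)ccc1Cl` carries an amide whose carbonyl carbon bears a 4-chloro-3-(trifluoromethyl)phenyl group. In a functional assay on HT-29 cells (Homo sapiens) for inhibition, read by sulforhodamine B assay, with a stated time of 48 h (a higher number here means that more compound is tolerated, a lower number that less compound is tolerated), compound 2 reaches only a limit, > 32500 nM, so for it no number is known. Compound 1 `COc1cc(-c2nn(-c3cccc(NC(=O)Nc4cccc(C(F)(F)F)c4)c3)cc2-c2ccncc2)ccc1Cl` is its closest measured relative, differing only at the carbonyl carbon, where a (3-(trifluoromethyl)phenyl)amino group gives a urea. In this assay compound 1 gives 4670 nM. Going by the values given here, the one measured step, an at least 6.9-fold higher number from compound 1 to compound 2 (0.84 log units; beyond the scatter), shows that swapping the urea for the amide pushes the number up, a change marked by the limit of > 32500 nM in this assay, at which 1 of the 2 values shown sits.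

Compound 3 `COc1cc(-c2nn(-c3cccc(NC(=O)Nc4ccc(Cl)c(C(F)(F)F)c4)c3)cc2-c2ccncc2)ccc1Cl` has not been measured. It differs from compound 2 by (4-chloro-3-(trifluoromethyl)phenyl)amino in place of 4-chloro-3-(trifluoromethyl)phenyl on a carbonyl carbon, so the amide becomes a urea again while the chlorine on the outer ring stays. Among the compounds with values here, that is the reverse of the one measured step, so a lower number in this assay is expected for compound 3, likely of a size similar to that step, which means a return toward the number of compound 1. The expected step is an at least 7.2-fold lower number from compound 2 to compound 3 (0.85 log units; beyond the scatter). For compound 3 the estimated value is 4500 nM, within a range from 1500 nM to 14000 nM.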

Compound 3, concentration lethal to 50% of the cells: 21500 nM
Compound 3: middle estimate off by 4.8-fold (0.68 log units), on the low side; measured number outside the range, above it.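

Compound 3 separates two changes that arrived together in the step to compound 2, the added chlorine on the outer ring and the loss of the urea nitrogen. With the urea kept, chloro in place of hydrogen on an aromatic carbon gives a 4.6-fold higher number from compound 1 to compound 3 (0.66 log units; beyond the scatter) in this assay, so this one atom alone moves the number upward, towards more compound being tolerated. On these data alone, with the chlorine kept, putting the urea back in place of the amide gives an at least 1.5-fold lower number from compound 2 to compound 3 (0.17 log units; that floor lies within the scatter), so the data do not show that this change matters, and the true size of the step stays unknown because compound 2 reaches only a limit: the limit of > 32500 nM in this assay, at which 1 of the 3 values shown sits.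

The compounds shown leave open whether the effect belongs to chlorine in particular or would also appear with a fluorine atom or a methyl group in its place on the outer ring. Also open, as far as these compounds go, is how an amide bearing a plain 3-(trifluoromethyl)phenyl group, with no chlorine, would compare with compound 1, which would test the urea-to-amide change on its own.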